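Substituent changes at one aromatic carbon, shared core

The source may hold more compounds than are shown below. What is called first, only, known or untested is meant among the compounds shown, and "the series" means these compounds.

Measured in a functional assay on SW-620 cells (Homo sapiens) for cytotoxicity, read by MTT assay, with a stated time of 72 h; on this read-out higher numbers stand for weaker inhibition and lower numbers for stronger inhibition:
- compound 1, `O=C1N/C(=N/c2csc(-c3ccc(Cl)cc3)c2)S/C1=C\c1ccccc1`: > 50000 nM (a limit of the assay, not a number)
- compound 2, `Cc1ccc(/C=C2\S/C(=N\c3csc(-c4ccc(Cl)cc4)c3)NC2=O)cc1`: 1500 nM
- compound 3, `CN(C)c1ccc(/C=C2\S/C(=N\c3csc(-c4ccc(Cl)cc4)c3)NC2=O)cc1`: 800 nM

Compound 3 gives the lowest number shown in this assay; its nearest neighbour is compound 2, and the two lie within the scatter of each other, so no order between them is claimed. Compound 1 sits at the limit of > 50000 nM in this assay, at which 1 of the 3 values shown sits.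

Compound 4, `O=C1N/C(=N/c2csc(-c3ccc(Cl)cc3)c2)S/C1=C\c1ccc(Br)cc1`, is not yet measured. It differs from compound 3 in one place: bromo in place of dimethylamino on an aromatic carbon.

For the measured compounds named here, three measured steps touch this carbon. an at least 33-fold lower number from compound 1 to compound 2 (1.52 log units; beyond the scatter) and an at least 62-fold lower number from compound 1 to compound 3 (1.79 log units; beyond the scatter) show that a group at this position matters greatly against the unsubstituted parent, while a 1.9-fold lower number from compound 2 to compound 3 (0.27 log units; within the scatter) shows that exchanging one such group for another moved the number little. Bromo has no precedent here, so a number near those of compound 2 and compound 3 is expected, with a step of a 1.9-fold higher number from compound 3 to compound 4 (0.27 log units; within the scatter) not expected to exceed the scatter by much, though a return toward the limit cannot be excluded.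

Compound 4 is estimated at 1500 nM, with a range from 400 nM to 15000 nM.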

Compound 4, half-maximal inhibitory concentration: 700 nM
Compound 4: the middle estimate sits 2.1-fold (0.33 log units) above what was measured; the measured number falls inside the stated range.
By their numbers in this assay, from the lowest: compounds 4, 3 and 2 (each within the scatter of the next, the first and the last beyond it). At a limit, above all of these: compound 1.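

Bromo, one heavy atom with no hydrogen-bond acceptor, does as well here as the larger dimethylamino (a 1.1-fold lower number from compound 3 to compound 4 (0.06 log units; within the scatter)), so neither that acceptor nor the extra heavy atoms are needed for a number of this size in this pair. Exchanging one group for another at this carbon can pass the scatter, though only modestly (a 2.1-fold lower number from compound 2 to compound 4 (0.33 log units; beyond the scatter)), which the step between compound 2 and compound 3 did not do. A third group now parts clearly from the unsubstituted parent (an at least 71-fold lower number from compound 1 to compound 4 (1.85 log units; beyond the scatter)), and compound 1 remains a limit, not a number: the limit of > 50000 nM in this assay, at which 1 of the 4 values shown sits.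

Going by these compounds, whether a carboxylic acid, a primary amine or a longer chain at this carbon would keep the number in this range stays open. The compounds shown also leave open whether bromo would give a similar number at another carbon of the same ring.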